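Hydroxy on the pendant phenyl: from compound 1 to compound 4

A few compounds are considered here, and "the series" means these few. Any claim that something is new, unique, unknown or untested is made for them only; others in the source may bear on it.

Compound 1, `COc1cc(-n2cnc3ccc(-c4ccccc4)cc32)cc(OC)c1OC`, gives 3060 nM in a functional assay on A549 cells (Homo sapiens) for antiproliferative activity, read by MTT assay, with a stated time of 72 h; on this read-out higher numbers stand for weaker inhibition and lower numbers for stronger inhibition.
Compound 2, `COc1cc(-n2cnc3ccc(-c4cccc(O)c4)cc32)cc(OC)c1OC`, gives 250 nM.
Compound 3, `COc1cc(-n2cnc3ccc(-c4cccc([N+](=O)[O-])c4)cc32)cc(OC)c1OC`, gives 5410 nM.

Among these three numbers compound 1 stands second highest. Its nearest neighbour is compound 3: a 1.8-fold higher number from compound 1 to compound 3 (0.25 log units; within the scatter), a difference that stays within the usual scatter. Its furthest neighbour is compound 2: a 12-fold lower number from compound 1 to compound 2 (1.09 log units; beyond the scatter), a large and clearly real improvement. The step between the other two, a 22-fold higher number from compound 2 to compound 3 (1.34 log units; beyond the scatter), is large as well.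

Compound 4, `COc1cc(-n2cnc3ccc(-c4ccc(O)cc4)cc32)cc(OC)c1OC`, differs from compound 1 in one respect: hydroxy in place of hydrogen on an aromatic carbon. For the measured compounds named here, the one measured step that bears on this is the one from compound 1 to compound 2, where the change is likewise from hydrogen to hydroxy, though the hydroxy of compound 2 does not sit where that of compound 4 does, and which brought a 12-fold lower number from compound 1 to compound 2 (1.09 log units; beyond the scatter). On that basis a lower number is expected for compound 4 in this assay, probably a sizeable step, but with wide uncertainty since the place of the hydroxy is not the same. The expected step is a 5.1-fold lower number from compound 1 to compound 4 (0.71 log units; beyond the scatter). Compound 4 is estimated at 600 nM, with a likely range from 150 nM to 2500 nM.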

Compound 4, half-maximal inhibitory concentration: 5090 nM
Compound 4: middle estimate off by 8.5-fold (0.93 log units), on the low side, and the stated range ends below it.
By their numbers in this assay, from the lowest: compound 2; then compounds 1, 4 and 3 (each within the scatter of the next).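

Compound 4 shows that a hydroxy on the pendant phenyl is not enough in itself to strengthen inhibition in this assay: placed para to a large group, it leaves the number within the usual scatter of the unsubstituted phenyl (a 1.7-fold higher number from compound 1 to compound 4 (0.22 log units; within the scatter)), and also within the scatter of the nitro compound (a 1.1-fold lower number from compound 3 to compound 4 (0.03 log units; within the scatter)). The large gain of compound 2 therefore belongs to the hydroxy in its particular place on the ring, not to the hydroxy as such, since compounds 2 and 4 differ only in that place and stand far apart (a 20-fold higher number from compound 2 to compound 4 (1.31 log units; beyond the scatter)). Nothing given here explains why the place of this one group matters so much.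

On these data alone, whether the gain of compound 2 is particular to hydroxy remains open, and an amine, a methoxy or a carboxylic acid at the same place on the ring would be the direct test. Also open, as far as these compounds go, is whether a longer chain carrying a hydroxy, or a second hydroxy on the same phenyl, would keep, lose or add to that gain.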